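Replacing the morpholine of compound 1 with pyrrolidine

The source may report more compounds than this note shows. Statements on the series, on what has been measured and on what is new or still open speak of the compounds shown alone.

Compound 1 `N/C(=N\NC(=S)N1CCOCC1)c1ccccn1` is the reference point of this small set. Going by the values given here, in a functional assay on MCF7 cells (Homo sapiens) for cytotoxicity, read by MTT assay, with a stated time of 72 h, tested at 3 uM (a lower number here means less inhibition of growth, a higher number more inhibition of growth at the concentration tested), compound 1 gives 44.5%, the highest of the three numbers so far. Its two methylated relatives sit lower: compound 2 `Cc1ccnc(/C(N)=N/NC(=S)N2CCOCC2)c1` gives 5.07% in this assay, and compound 3 `Cc1cccc(/C(N)=N/NC(=S)N2CCOCC2)n1` gives 21.6%. Both steps are beyond the scatter, a number 39.4 percentage points lower from compound 1 to compound 2 (beyond the scatter) and a number 22.9 percentage points lower from compound 1 to compound 3 (beyond the scatter), and each involves a methyl in place of hydrogen on an aromatic carbon.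

Compound 4 `N/C(=N\NC(=S)N1CCCC1)c1ccccn1` changes a different part of the shared core: pyrrolidin-1-yl in place of morpholin-4-yl on a thiocarbonyl carbon. Among the compounds with values here, neither measured step touches the thiocarbonyl carbon or the ring attached to it, so no measured step bears directly on this change, and the pyridine-side losses of compound 2 and compound 3 cannot be transferred to it. Lacking a guiding step, the expectation is no change beyond the scatter, a number 4.5 percentage points lower from compound 1 to compound 4 (within the scatter), with a wide allowance either way. Compound 4 is therefore estimated at 40% in this assay, expected between 15% and 65%.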

Compound 4, percent growth inhibition at one concentration: 49.8%
Compound 4: the middle estimate sits 9.8 percentage points below what was measured; the range from low to high includes it.
By their numbers in this assay, from the lowest: compound 2; then compound 3; then compounds 1 and 4 (each within the scatter of the next).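

In this assay, going by these compounds alone, pyrrolidin-1-yl in place of morpholin-4-yl on a thiocarbonyl carbon gives a number 5.3 percentage points higher from compound 1 to compound 4 (within the scatter), the first measured step at this place in the shared core. Whereas both methyl steps lay beyond the scatter, this one shows that morpholin-4-yl, with its oxygen and its hydrogen-bond acceptor, can give way to the smaller pyrrolidin-1-yl without a change that can be told from the scatter in this read-out. No measurement shown here offers an explanation for this result.

Still open, from the compounds shown here alone, is whether this place accepts groups further from these two rings, such as an open-chain dimethylamino group or a piperazine ring carrying a free amine. Going by these compounds, it is also open whether the methyl steps seen with morpholin-4-yl would carry over to compounds bearing pyrrolidin-1-yl.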